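Propoxy to methyl on the shared core: expected cytotoxicity

The source may report more compounds than this note shows. Statements on the series, on what has been measured and on what is new or still open speak of the compounds shown alone.

Measured so far:
compound 1 `CCCOc1ccc2oc(/C=C/[S+](C)[O-])cc(=O)c2c1` — 1100 nM
compound 2 `COc1cccc2c(=O)cc(/C=C/[S+](C)[O-])oc12` — 2200 nM

Two compounds have numbers in a functional assay on A549 cells (Homo sapiens) for cytotoxicity, with a stated time of 48 h; a higher number here means a weaker inhibitor, a lower number a stronger inhibitor. Compound 1 gives 1100 nM and stands at the lower of the two; compound 2 gives 2200 nM, a gap that lies within the scatter, so the two are not separated by this assay.

Compound 3 `Cc1ccc2oc(/C=C/[S+](C)[O-])cc(=O)c2c1` is not yet measured. It differs from compound 1 in one place: methyl in place of propoxy on an aromatic carbon. Going by the values given here, no step between measured compounds exists for this kind of change, so there is nothing to set its size. The expectation is a small shift toward a higher number, quite possibly not beyond the scatter, with the step from compound 1 estimated as a 1.6-fold higher number from compound 1 to compound 3 (0.21 log units; within the scatter). Compound 3 is therefore expected to give about 1800 nM in this assay, within a range of 600 nM to 5500 nM.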

Compound 3, half-maximal inhibitory concentration: 1700 nM
Beside the measured number, compound 3's estimate is 1.1-fold (0.02 log units) above it; low and high end bracket the measured number.
By their numbers in this assay, from the lowest: compounds 1, 3 and 2 (each within the scatter of the next).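

In this assay, the position on the aromatic carbon now has its first step between compounds that differ in one place: methyl in place of propoxy gives a 1.5-fold higher number from compound 1 to compound 3 (0.19 log units; within the scatter) and so does not separate the two compounds. On the shared core, this position therefore carries either the propoxy chain or the much smaller methyl without a shift beyond the scatter, although this rests on a single pair. Nothing available gives a reason for the size of this step.

As far as these compounds go, whether any group at this position can move the number beyond the scatter remains open, and an amine, a carboxylic acid or a longer alkoxy chain such as hexyloxy would each test that. Also open, from the compounds shown here alone, is whether the same change gives a similar step elsewhere on the shared core.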